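From compound 2 to compound 4: growth inhibition notes

The compounds below may be only part of what the source reports. "The series", "measured", "known", "first", "only" and "open" are said of these compounds alone.

Values so far in an ADME assay on L02 cells (Homo sapiens) for inhibition, read by CCK-8 assay, with a stated time of 48 h (on this read-out lower numbers stand for stronger inhibition of growth and higher numbers for weaker inhibition of growth), for this series
Compound 1 (`Cc1ccccc1Nc1nc(NC2CC2)ncc1Cl`) gives > 100000 nM as a limit
Compound 2 (`Cc1ccccc1Nc1nc(Nc2ccccc2)ncc1Cl`) gives > 100000 nM as a limit
Compound 3 (`Cc1ccccc1Nc1nc(NCc2ccccc2)ncc1Cl`) gives > 100000 nM as a limit

Compound 2 stands only at its limit of > 100000 nM and carries no number. Compound 4 (`Cc1ccccc1Nc1nc(Nc2ccc(N3CCN(C)CC3)cc2)ncc1Cl`) differs from it by 4-methylpiperazin-1-yl in place of hydrogen on an aromatic carbon (4-methylpiperazin-1-yl in place of hydrogen on an aromatic carbon, para to a large group). Bearing on this are a step that the two limits leave unreadable from compound 1 to compound 2 and a step that the two limits leave unreadable from compound 1 to compound 3 and a step that the two limits leave unreadable from compound 2 to compound 3 and none has a readable size. The evidence is the limit of > 100000 nM in this assay, at which 3 of the 3 values shown sit, and so offers no size to carry over. In this assay a step towards stronger inhibition of growth is expected on the structural change alone, and another limit remains possible. The expected step is an at least 2.0-fold lower number from compound 2 to compound 4 (0.30 log units; that floor lies within the scatter) as an estimate only. Compound 4 is estimated at 50000 nM in an expected range from 12000 nM to 150000 nM for now.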

Compound 4, concentration for 50% growth inhibition: 6510 nM
Compound 4: middle estimate off by 7.7-fold (0.89 log units), on the high side; the measured number lies below the stated range.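

In this assay, 4-methylpiperazin-1-yl in place of hydrogen on an aromatic carbon, para to a large group, gives an at least 15-fold lower number from compound 2 to compound 4 (1.18 log units; beyond the scatter). That size is only a floor, as compound 2 carries a limit and no number. The steps among compound 1, compound 2 and compound 3 cannot be read, so this is the first change in the series to reach a measured number: the limit of > 100000 nM in this assay, at which 3 of the 4 values shown sit.

As far as these compounds go, whether the step needs the whole 4-methylpiperazin-1-yl group stays open. A morpholine or a dimethylamino group on the same carbon could separate the ring from its second nitrogen.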